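The source may report more compounds than this note shows. Statements on the series, on what has been measured and on what is new or still open speak of the compounds shown alone.

In an ADME assay on microsomes from liver (Rattus norvegicus), read by LC-MS, using NADPH, with a stated time of 10 min, tested at 0.5 uM (on this read-out higher numbers stand for a more stable compound and lower numbers for a less stable compound), compound 1 `Cc1nc2cc(-c3cccc(-c4ccccc4)c3)nn2c(-c2cc(F)c3c(c2C)CCCO3)c1[C@H](OC(C)(C)C)C(=O)O` gives 96% and compound 2 `Cc1nc2cc(-c3cccc(-c4ccccc4)c3)nn2c(-c2cc(F)c3c(c2C)CCCO3)c1C(OC(C)(C)C)C(=O)O` gives 100% with the same atoms and bonds and its stereocentre drawn without a configuration. Compound 3 `Cc1nc2cc(-c3cccc(-c4ccncc4)c3)nn2c(-c2cc(F)c3c(c2C)CCCO3)c1[C@H](OC(C)(C)C)C(=O)O` carries pyridin-4-yl in place of phenyl on an aromatic carbon. Going by the values given here, the one measured step (a number 4 percentage points higher from compound 1 to compound 2 (within the scatter)) concerns the stereocentre and not this ring, so it gives no measure of the exchange, and no change beyond the scatter is expected. The estimated step (a number 4 percentage points lower from compound 1 to compound 3 (within the scatter)) is accordingly small. In this assay compound 3 is expected at 92% within an estimated range (78% to 100%).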

Compound 3, percent of the compound remaining: 94%
Compound 3: middle estimate off by 2 percentage points, on the low side; the measured number falls inside the stated range.
By their numbers in this assay, from the lowest: compounds 3, 1 and 2 (each within the scatter of the next).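

Going by these compounds alone, the exchange of phenyl for pyridin-4-yl, which the earlier compounds left untouched, now has a measured step in this assay: a number 2 percentage points lower from compound 1 to compound 3 (within the scatter). On this aromatic carbon, meta to a large group, a ring nitrogen with its hydrogen-bond acceptor therefore enters without a change beyond the scatter. Nothing measured here accounts for this outcome. As far as these compounds go, it remains open whether pyridin-3-yl, or a phenyl carrying an amine or a carboxylic acid, would read alike in this assay at this place.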